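Dropping the second chloro: compound 2 to compound 4

The source may hold more compounds than are shown below. What is called first, only, known or untested is meant among the compounds shown, and "the series" means these compounds.

- compound 1 `COc1ccc(Cn2ncc3c2NC(=O)CC(c2cccc(NC(=O)Nc4cccc(Cl)c4)c2)=N3)cc1` gives 630 nM
- compound 2 `COc1ccc(Cn2ncc3c2NC(=O)CC(c2cccc(NC(=O)Nc4cc(Cl)cc(Cl)c4)c2)=N3)cc1` gives 6480 nM
- compound 3 `O=C1CC(c2cccc(NC(=O)Nc3ccc(Cl)c(Cl)c3)c2)=Nc2cn[nH]c2N1` gives > 30000 nM as a limit, not a number

In a functional assay on U-937 cells (Homo sapiens) for inhibition, read by MTT assay, with a stated time of 24 h (on this read-out higher numbers stand for weaker inhibition of growth and lower numbers for stronger inhibition of growth), compound 2 at 6480 nM is the higher of the two actual numbers. The next structure, compound 4 `COc1ccc(Cn2ncc3c2NC(=O)CC(c2cccc(NC(=O)Nc4cccc(C(F)(F)F)c4)c2)=N3)cc1`, differs from it by 3-(trifluoromethyl)phenyl in place of 3,5-dichlorophenyl on an amide-type nitrogen with 3-(trifluoromethyl)phenyl in place of 3,5-dichlorophenyl on an amide-type nitrogen. Among the compounds with values here, one measured step bears on this, and it is large: a 10-fold higher number from compound 1 to compound 2 (1.01 log units; beyond the scatter) on adding chloro in place of hydrogen on an aromatic carbon. Leaving the 3,5-dichlorophenyl may undo much of that step, though no step involving trifluoromethyl has been measured. The estimated change in this assay is a 6.5-fold lower number from compound 2 to compound 4 (0.81 log units; beyond the scatter) and is expected to be somewhat smaller than that measured step. Compound 4 is estimated at 1000 nM with an expected range from 300 nM to 4000 nM in this read-out.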

Compound 4, concentration for 50% growth inhibition: 280 nM
The estimate for compound 4 lay 3.6-fold (0.55 log units) above the measured number, outside the stated range (below it).
By their numbers in this assay, from the lowest: compound 4; then compound 1; then compound 2. At a limit, above all of these: compound 3.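

In this assay, the position on the amide-type nitrogen is not simply closed to larger groups: 3-(trifluoromethyl)phenyl in place of 3,5-dichlorophenyl gives a 23-fold lower number from compound 2 to compound 4 (1.36 log units; beyond the scatter) and more than recovers the loss that came with the second chloro. Trifluoromethyl in place of chloro gives a 2.3-fold lower number from compound 1 to compound 4 (0.35 log units; beyond the scatter) and so separates compound 4 from compound 1 by a modest but real step. Nothing shown on measured properties bears on why these steps arise. As far as these compounds go, whether an amine or a nitrile at this aromatic carbon would hold the lower number remains open.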